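The compounds below may be only part of what the source reports. "The series", "measured", "known", "first", "only" and "open" are said of these compounds alone.

Three compounds have values so far in a physicochemical assay for solubility, using the shake flask method, measured as kinetic solubility, with a stated time of 20 h, at pH 2 (a higher number here means a more soluble compound, a lower number a less soluble compound), as follows:
Compound 1 `FC(F)(F)c1cccc(-c2nc3cnc(Nc4ccncn4)cc3[nH]2)c1` gives 200000 nM
Compound 2 `Fc1ccc(-c2nc3cnc(Nc4ccccn4)cc3[nH]2)cc1C(F)(F)F` gives 7000 nM
Compound 3 `Fc1ccc(-c2nc3cnc(Nc4ccccn4)cc3[nH]2)cc1F` gives 125000 nM

The values of compound 3 and compound 1 lie within the scatter of each other, and together they form the high end of these three numbers. Among the compounds with values here, the one measured step that reaches compound 3 is an 18-fold higher number from compound 2 to compound 3 (1.25 log units; beyond the scatter) and it is fluoro in place of trifluoromethyl on an aromatic carbon.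

Compound 4 `Fc1ccc(-c2nc3cnc(Nc4ccc(C(F)(F)F)cn4)cc3[nH]2)cc1F` differs from compound 3 by a single change, trifluoromethyl in place of hydrogen on an aromatic carbon which is trifluoromethyl in place of hydrogen on an aromatic carbon. The measured step bears on this only loosely. There trifluoromethyl leaves, here it enters, and the place is a different one. Within the data shown here, no measured pair shows hydrogen giving way to trifluoromethyl. Taken backwards, the step of an 18-fold higher number from compound 2 to compound 3 (1.25 log units; beyond the scatter) still points to a lower number for compound 4 in this assay and a large drop is expected, though its size is uncertain. The estimated change is a 10-fold lower number from compound 3 to compound 4 (1.02 log units; beyond the scatter) on this reading. For compound 4 the expected value is 12000 nM with an estimated range from 2500 nM to 50000 nM across repeated measurements.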

Compound 4, solubility: 6000 nM
The estimate for compound 4 lay 2.0-fold (0.30 log units) above the measured number; low and high end bracket the measured number.
By their numbers in this assay, from the lowest: compounds 4 and 2 (each within the scatter of the next); then compounds 3 and 1 (each within the scatter of the next).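

Within the data shown here, this is the first measured pair in which hydrogen gives way to trifluoromethyl, here on an aromatic carbon of a six-membered aromatic ring with 1 nitrogen, two atoms from the ring nitrogen and para to a large group, and in this assay it brings a 21-fold lower number from compound 3 to compound 4 (1.32 log units; beyond the scatter) as a large step. The earlier step, an 18-fold higher number from compound 2 to compound 3 (1.25 log units; beyond the scatter), concerned another place and had fluoro rather than hydrogen as the other group, so the two steps now agree in direction at two separate places: the compound with trifluoromethyl gives the lower number in each pair, although compound 1 goes against any wider pattern, carrying trifluoromethyl and giving 200000 nM in the same assay. No measurement available here accounts for the size or direction of the new step.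

The compounds shown leave open how this place responds to other groups, such as an amine, a methoxy group or a carboxylic acid, and so whether the large step is particular to trifluoromethyl. They also leave open whether the same change would bring a step of similar size on the core of compound 1, whose attached ring differs.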